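The source may hold more compounds than are shown below. What is called first, only, known or untested is meant among the compounds shown, and "the series" means these compounds.

Compound 1 `COc1cc(/C=C/c2ccc(NC(=O)/C=C/c3ccc(OC)c(OC)c3)cc2)cc(OC)c1`: 7740 nM
Compound 2 `COc1cc(/C=C/c2ccc(NC(=O)/C=C/c3ccc(F)cc3)cc2)cc(OC)c1`: 9390 nM
Compound 3 `COc1cc(/C=C/c2ccc(NC(=O)/C=C/c3ccc(Br)cc3)cc2)cc(OC)c1`: 6160 nM

Of the compounds shown here, three built on one shared core have been tested in a functional assay on MDA-MB-231 cells (Homo sapiens) for inhibition, read by MTT assay, with a stated time of 48 h; on this read-out lower numbers stand for stronger inhibition and higher numbers for weaker inhibition. Compound 1 stands second highest of the three numbers. Its nearest neighbour is compound 2, reached by a 1.2-fold higher number from compound 1 to compound 2 (0.08 log units; within the scatter), and its furthest is compound 3, reached by a 1.3-fold lower number from compound 1 to compound 3 (0.10 log units; within the scatter). Compound 4 `COc1cc(/C=C/c2ccc(NC(=O)/C=C/c3ccc(O)c(O)c3)cc2)cc(OC)c1` has not yet been measured. It differs from compound 1 in one place: 3,4-dihydroxyphenyl in place of 3,4-dimethoxyphenyl on a double-bonded chain carbon bound to a double-bonded chain carbon.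

Both measured steps that start from compound 1 also exchange the 3,4-dimethoxyphenyl for another group at the same position, and both stayed within the scatter, as did the step of a 1.5-fold lower number from compound 2 to compound 3 (0.18 log units; within the scatter) between the other two compounds. Among the measured compounds shown here, no measured step puts a 3,4-dihydroxyphenyl in this place, so the expectation rests on the observation that the three measured groups at this position all gave numbers within the scatter of one another. Compound 4 is therefore expected to come out at about 7500 nM, within a range from 3500 nM to 16000 nM. The expected step is a 1.0-fold lower number from compound 1 to compound 4 (0.01 log units; within the scatter), with no direction beyond the scatter.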

Compound 4, half-maximal inhibitory concentration: 4230 nM
The estimate for compound 4 lay 1.8-fold (0.25 log units) above the measured number, within the range that was stated.
By their numbers in this assay, from the lowest: compounds 4, 3, 1 and 2 (each within the scatter of the next, the first and the last beyond it).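

In this assay, among the compounds shown here, the 3,4-dihydroxyphenyl gives the first step at this place that lies beyond the scatter, though only a modest one (a 2.2-fold lower number from compound 2 to compound 4 (0.35 log units; beyond the scatter)), whereas the three earlier groups all stayed within the scatter of one another. Against the other two groups it does not separate (a 1.8-fold lower number from compound 1 to compound 4 (0.26 log units; within the scatter); a 1.5-fold lower number from compound 3 to compound 4 (0.16 log units; within the scatter)), so exchanging 3,4-dimethoxyphenyl for 3,4-dihydroxyphenyl, which brings in two hydrogen-bond donors, cannot be told from no change. For the compounds shown here, no measurement at hand bears on why the one step beyond the scatter arises.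

The compounds shown leave open whether a phenyl carrying a single hydroxyl, an amine or a carboxylic acid would move the number clearly away from this group. They also leave open whether any group at this place can give a larger step than the modest one seen here.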